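A few compounds are considered here, and "the series" means these few. Any claim that something is new, unique, unknown or untested is made for them only; others in the source may bear on it.

Compound 3 `O=C1C2CCCCN2C(=O)N1CN1CCN(c2ccccc2)CC1` was tested in an assay on isolated protein for binding affinity to Adrenergic receptor alpha-1 (Rattus norvegicus), read by radioligand binding; on this read-out higher numbers stand for weaker inhibition and lower numbers for stronger inhibition. For compound 3 the result is only a limit, > 1000 nM, and not a number. Compound 3 shares its core, apart from the size of one saturated ring, with compound 1 `O=C1C2CCCN2C(=O)N1CN1CCN(c2ccccc2)CC1`, and in this assay compound 1 gives 1000 nM. Compound 2 `O=C1C2CCCN2C(=O)N1CN1CCN(c2cccc(C(F)(F)F)c2)CC1` carries a trifluoromethyl group on the phenyl ring. For compound 2 the assay again reports only a limit, > 1000 nM. Among the measured compounds shown here, the step of a number no lower from compound 1 to compound 2 (the limit leaves the size open) is the only measured change on the phenyl ring, and its size cannot be read.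

Compound 4 `O=C1C2CCCCN2C(=O)N1CN1CCN(c2cccc(Cl)c2)CC1` differs from compound 3 by chloro in place of hydrogen on an aromatic carbon. For the measured compounds named here, this change, like the one from compound 1 to compound 2, puts a group on an aromatic carbon of the phenyl ring. Little movement is expected because the limit of > 1000 nM in this assay, at which 2 of the 3 values shown sit, leaves the measured steps without a readable size. Compound 4 is therefore expected to give about 3000 nM, between 1000 nM and 10000 nM, most likely again as a limit. The expected step that the limit leaves unreadable from compound 3 to compound 4 is no change beyond the scatter.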

Compound 4, inhibition constant: 135 nM
Compound 4: the middle estimate sits 22-fold (1.35 log units) above what was measured; measured number outside the range, below it.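

In this assay, chloro in place of hydrogen on an aromatic carbon, meta to a large group, gives an at least 7.4-fold lower number from compound 3 to compound 4 (0.86 log units; beyond the scatter). This shows that one added chlorine atom at this place on the phenyl ring can bring a compound clear of the assay limit, so a change on this ring can have a size that is at least partly readable. No earlier step showed this, as the earlier step on the phenyl ring cannot be read: the limit of > 1000 nM in this assay, at which 2 of the 4 values shown sit.

From the compounds shown here alone, whether chloro would give a similar step on the core of compound 1 remains open, as does the exact size of the step, which starts from a limit. Going by these compounds, it is also open how a methoxy group or an amine at this same place would compare with chloro.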